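Pyridine to pyrimidine on the amide arm: working notes

A few compounds are considered here, and "the series" means these few. Any claim that something is new, unique, unknown or untested is made for them only; others in the source may bear on it.

Measured so far in a functional assay on cells for agonist activity at D(4) dopamine receptor (Homo sapiens), read by TR-FRET and cAMP accumulation, with a stated time of 30 min; on this read-out higher numbers stand for larger maximal responses and lower numbers for smaller maximal responses:
compound 1 `CCc1cccc(NC(=O)CN2CCN(c3ccccn3)CC2)c1`, 58%
compound 2 `O=C(CN1CCN(c2ccccn2)CC1)Nc1cccnc1`, 47.3%

For the measured compounds named here, compound 2 stands lowest of the two numbers in this assay; the only measured step is a number 10.7 percentage points lower from compound 1 to compound 2 (beyond the scatter). Compound 3 `O=C(CN1CCN(c2ccccn2)CC1)Nc1cncnc1` differs from compound 2 by pyrimidin-5-yl in place of pyridin-3-yl on an amide-type nitrogen. Going by the values given here, no measured step covers this change directly; the one step known also swapped the ring on the amide-type nitrogen and gave a modest drop, so a small decrease or no step beyond the scatter is expected in this assay. Compound 3 is estimated at 40%, range 25% to 55%, which means an expected step of a number 7.3 percentage points lower from compound 2 to compound 3 (within the scatter).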

Compound 3, largest response reached (Emax), in percent of the reference or control that the assay uses: "not active" (no number reported)
For compound 3 the study gives words and no number; no gap can be computed for the estimate.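

For the compounds shown here, compound 3 is reported in words only in this assay, and no step from compound 2 to compound 3 can be read. The compounds shown leave open how large any maximal response of compound 3 might be relative to compound 2. No evidence at hand bears on this result.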